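The compounds below may be only part of what the source reports. "The series", "measured", "known", "first", "only" and "open" are said of these compounds alone.

Working notes on the series. Compound 1 `C=C1CC[C@@H]2[C@](C)(COC(C)=O)[C@H](O)CC[C@@]2(C)[C@@H]1C/C=C1/C(=O)OC[C@H]1Oc1cccc2ccc(C)nc12` and compound 2 `C=C1CC[C@H]2[C@@](C)(CCC(=O)[C@@]2(C)COC(C)=O)[C@@H]1C/C=C1/C(=O)OC[C@@H]1Oc1cccc2ccc(C)nc12` share the same side chain on the oxygen on a saturated carbon but differ in their cores; the difference between the two cores is not broken down here. In an ADME assay on Vero cells (Chlorocebus sabaeus) for cytotoxicity, read by MTT assay, with a stated time of 48 h (a lower number here means that less compound is tolerated, a higher number that more compound is tolerated), compound 1 gives 50600 nM and compound 2 gives 46700 nM, within the scatter of each other. Compound 3 `C=C1CC[C@H]2[C@@](C)(CCC(=O)[C@@]2(C)COC(C)=O)[C@@H]1C/C=C1/C(=O)OC[C@@H]1Oc1c(Cl)cc(Cl)c2cccnc12` is made from compound 2 by 5,7-dichloroquinolin-8-yl in place of 2-methylquinolin-8-yl on an oxygen on a saturated carbon; in this assay compound 3 gives 57400 nM, and the step of a 1.2-fold higher number from compound 2 to compound 3 (0.09 log units; within the scatter) is within the scatter. Compound 4 `C=C1CC[C@@H]2[C@](C)(COC(C)=O)[C@H](O)CC[C@@]2(C)[C@@H]1C/C=C1/C(=O)OC[C@H]1Oc1c(Cl)cc(Cl)c2cccnc12` is made from compound 1 by the same change, (5,7-dichloroquinolin-8-yl in place of 2-methylquinolin-8-yl on an oxygen on a saturated carbon), on a place described in the same words. Because a 1.2-fold higher number from compound 2 to compound 3 (0.09 log units; within the scatter) was flat, the step from compound 1 to compound 4 is expected to be a 1.1-fold higher number from compound 1 to compound 4 (0.06 log units; within the scatter) in this assay, that is, also within the scatter. Compound 4 is thus estimated at 58000 nM, with an expected range from 35000 nM to 95000 nM.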

Compound 4, half-maximal cytotoxic concentration: 85000 nM
For compound 4 the middle estimate is 1.5-fold (0.17 log units) below the measured one; low and high end bracket the measured number.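

In this assay the change from 2-methylquinolin-8-yl to 5,7-dichloroquinolin-8-yl gives a 1.7-fold higher number from compound 1 to compound 4 (0.23 log units; within the scatter) on the core of compound 1. The two cores give steps that cannot be told apart: the same change on two cores in this assay, a 1.2-fold higher number (0.09 log units; within the scatter) from compound 2 to compound 3 and a 1.7-fold higher number (0.23 log units; within the scatter) from compound 1 to compound 4, 1.4-fold (0.14 log units) apart, within the scatter of two such steps. Going by these compounds alone, this shows that the change stays within the scatter on both cores, but it rests on only two pairs in a single assay, so it does not show that the same would hold on any further core.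

Open, from the compounds shown here alone, is whether a group other than these two quinolinyl groups, such as a simple phenyl ring or a chain carrying an amine or a carboxylic acid, would stay within the scatter on the same oxygen. Also open, going by these compounds, is whether either core would separate the two quinolinyl groups in any other assay.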